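Amide chain variation on the shared core: compound 4

This account rests on a few compounds, and the source may have more. Where it says the series, first, only, none or still open, it means among the compounds named here.

Three amides of the shared core have been measured in an ADME assay on HepG2 cells (Homo sapiens) for cytotoxicity, read by trypan blue exclusion, with a stated time of 48 h, in the presence of a further agent that is not named here; a higher number here means that more compound is tolerated, a lower number that less compound is tolerated. Compound 1 `COc1cccc(NC(=O)COc2cc(C)nc3ccc(OC)cc23)c1` gives 43000 nM. Compound 2 `COc1ccc2nc(C)cc(OCC(=O)NCCCc3ccccc3)c2c1` gives > 137000 nM, which is a limit of the assay. Compound 3 `C#CCNC(=O)COc1cc(C)nc2ccc(OC)cc12` gives > 176000 nM, which is also a limit of the assay. Compound 3 therefore stands at a limit, and one further compound in the set sits at a limit as well (the limit of > 176000 nM in this assay, at which 1 of the 3 values shown sits). Of the measured steps, an at least 3.1-fold higher number from compound 1 to compound 2 (0.50 log units; beyond the scatter) and an at least 4.0-fold higher number from compound 1 to compound 3 (0.61 log units; beyond the scatter) are readable, whereas a step that the two limits leave unreadable from compound 2 to compound 3 has both ends at a limit.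

Compound 4 `CCCCCNC(=O)COc1cc(C)nc2ccc(OC)cc12` varies the same position: butyl in place of ethynyl on a saturated chain carbon bound to an amide-type nitrogen. The step that bears on it, a step that the two limits leave unreadable from compound 2 to compound 3, shows propargyl and 3-phenylpropyl both at the limit, so a plain pentyl chain is expected to sit there too. For compound 4 the expected step in this assay is a step that the limit leaves unreadable from compound 3 to compound 4, none beyond the scatter. Compound 4 is estimated at 200000 nM, with the range 100000 nM to 400000 nM, and most likely reported only as a limit.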

Compound 4, half-maximal cytotoxic concentration: > 158000 nM
Compound 4: only a limit was reported; the forecaster's own chance of this, stated with the estimate: 70%; the middle value lies beyond the limit too.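

In this assay compound 4 also stands at a limit, so a plain pentyl chain on the amide-type nitrogen joins propargyl and 3-phenylpropyl there: the limit of > 158000 nM in this assay, at which 1 of the 4 values shown sits. Compound 4 carries neither the ring of compound 2 nor the triple bond of compound 3, so the chain reaches a limit without either feature, while the change from 3-methoxyphenyl gives an at least 3.6-fold higher number from compound 1 to compound 4 (0.56 log units; beyond the scatter). The steps among compound 2, compound 3 and compound 4 cannot be read, as both ends of each are limits.

Going by these compounds alone, compound 1 is the only amide here with a measured number, and it is also the only one with an aryl group directly on the nitrogen, so it remains open whether that holds for aryl amides generally or for 3-methoxyphenyl alone. Plain phenyl on the nitrogen, a decyl chain, or a chain ending in an amine or a carboxylic acid would each bear on this position.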